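The source may hold more compounds than are shown below. What is called first, only, known or untested is meant among the compounds shown, and "the series" means these compounds.

Of the compounds shown here, three have so far been measured in a functional assay on L1210 cells (Mus musculus) for antiproliferative activity; a higher number here means a more potent compound, by a factor of ten per unit of this negative logarithm, a lower number a less potent compound. Compound 1 `CN(C)/N=N/c1nc(Cc2ccccc2)[nH]c1C(N)=O` gives 2.89, the second highest of the three numbers. Compound 3 `CN(C)/N=N/c1cc(C#N)cc(C#N)c1` gives 2.78, which lies within the scatter of the number for compound 1. Compound 2 `CN(C)/N=N/c1ccc(C#N)cc1C(N)=O` gives 3.46, the highest of the three and beyond the scatter from compound 1. Compound 4 `CCCc1nc(/N=N/N(C)C)c(C(N)=O)[nH]1` has not yet been measured; it differs from compound 1 by ethyl in place of phenyl on a saturated chain carbon bound to an aromatic carbon. Among the compounds with values here, no pair of measured compounds shows a change of this kind, so nothing measured tells its size or direction. Compound 4 is therefore expected to stay close to compound 1, with a step of a number 0.09 log units lower from compound 1 to compound 4 (within the scatter) that falls within the scatter. The estimate for compound 4 in this assay is 2.8, with a range from 2.2 to 3.4.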

Compound 4, logarithm of the reciprocal of the active concentration, log(1/C): 3.42
Beside the measured number, compound 4's estimate is 0.62 log units below it; measured number outside the range, above it.
By their numbers in this assay, from the lowest: compounds 3 and 1 (each within the scatter of the next); then compounds 4 and 2 (each within the scatter of the next).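

In this assay, within the data shown here, ethyl in place of phenyl on a saturated chain carbon bound to an aromatic carbon gives a number 0.53 log units higher from compound 1 to compound 4 (beyond the scatter), the first measured change at this place. In this pair, the phenyl ring is therefore not needed for activity, and the smaller group, with 2 heavy atoms rather than 6, gives the higher number. Nothing available explains the direction of this step.

From the compounds shown here alone, whether a longer chain, such as butyl, or an amine at this place would raise the number further remains open. A single pair also cannot show whether the same change would act alike on another core.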